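A few compounds are considered here, and "the series" means these few. Any claim that something is new, unique, unknown or untested is made for them only; others in the source may bear on it.

Series notes: hydrazide-linked piperazines tested in a functional assay on thoracic aorta (Rattus norvegicus, strain Wister); a lower number here means a stronger inhibitor, a higher number a weaker inhibitor.

Compound 1 `CN1CCN(CC(=O)NNc2nncc3ccccc23)CC1` carries a methyl on the ring nitrogen; in this assay compound 1 gives 160000 nM. Compound 2 `CCOC(=O)N1CCN(CC(=O)NNc2nncc3ccccc23)CC1` is its ethoxycarbonyl analogue. In this assay compound 2 reaches only a limit of the assay and not a number, > 1000000 nM. The change is ethoxycarbonyl in place of methyl on an amine nitrogen in a ring and the step it made is an at least 6.2-fold higher number from compound 1 to compound 2 (0.79 log units; beyond the scatter); its size cannot be stated more closely because of the limit of > 1000000 nM in this assay, at which 1 of the 3 values shown sits.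

Compound 3 `CN1CCN(CCC(=O)NNc2nncc3ccccc23)CC1` has a longer linker between the piperazine and the hydrazide than compound 1; how the two cores differ is not broken down here. In this assay compound 3 gives 360000 nM, which is a higher number than the value of compound 1, beyond the usual scatter.

Compound 4 `CCOC(=O)N1CCN(CCC(=O)NNc2nncc3ccccc23)CC1` is to be measured in this assay. It stands to compound 3 as compound 2 stands to compound 1: the change is ethoxycarbonyl in place of methyl on an amine nitrogen in a ring, the same kind of change as before, made at a place described in the same words. The expected step from compound 3 to compound 4 is a 6.9-fold higher number from compound 3 to compound 4 (0.84 log units; beyond the scatter), resting on the step seen in an at least 6.2-fold higher number from compound 1 to compound 2 (0.79 log units; beyond the scatter) and on the starting value of compound 3, 360000 nM. Compound 4 is thus expected to give about 2500000 nM, estimated to lie between 700000 nM and 8000000 nM, and most likely to be reported only as a limit of the assay.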

Compound 4, half-maximal inhibitory concentration: > 1000000 nM
Compound 4 was reported as a limit; the forecaster's own chance of this, stated with the estimate: 75%; the middle value does not contradict the limit.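

In this assay compound 4 reaches only a limit of the assay, > 1000000 nM. Ethoxycarbonyl in place of methyl on an amine nitrogen in a ring gives an at least 2.7-fold higher number from compound 3 to compound 4 (0.44 log units; beyond the scatter), so the direction of the change seen on the core of compound 1 recurs on the core of compound 3, and the two steps stand together as follows: the same change on two cores in this assay, an at least 6.2-fold higher number (0.79 log units; beyond the scatter) from compound 1 to compound 2 and an at least 2.7-fold higher number (0.44 log units; beyond the scatter) from compound 3 to compound 4; the limit leaves it open whether they differ This shows that the direction carries over between these two cores, but it does not show that the size of the step carries over, and it gives no firm size for either step, because both ethoxycarbonyl compounds sit at the same ceiling: the limit of > 1000000 nM in this assay, at which 2 of the 4 values shown sit.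

The compounds shown leave open whether the longer linker of compound 3 alters the size of the step or only leaves less room for it to be read in this series. Also open, going by these compounds, is whether an ethyl, an acetyl or a free secondary amine on the same ring nitrogen would give numbers rather than limits on both cores, which would allow a change on that nitrogen to be compared from one core to the other.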